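Aryl terminus variation on the hydrazone series

A few compounds are considered here, and "the series" means these few. Any claim that something is new, unique, unknown or untested is made for them only; others in the source may bear on it.

Among the measured compounds shown here, the three measured members share one core and differ only in the aryl group on the carbon with a double bond to nitrogen. Compound 1 `COc1cc2c(Oc3ccc(NC(=O)N/N=C/c4ccc(C(F)(F)F)cc4)cc3F)ccnc2cc1OCCCN1CCCCC1` gives 1100 nM in a functional assay on MDA-MB-231 cells (Homo sapiens) for cytotoxicity, read by MTT assay, with a stated time of 72 h; on this read-out lower numbers stand for stronger inhibition and higher numbers for weaker inhibition. Compound 2 `COc1cc2c(Oc3ccc(NC(=O)N/N=C/c4ccc(F)cc4Cl)cc3F)ccnc2cc1OCCCN1CCCCC1` gives 790 nM. Compound 3 `COc1cc2c(Oc3ccc(NC(=O)N/N=C/c4ccc(OC(F)(F)F)cc4)cc3F)ccnc2cc1OCCCN1CCCCC1` gives 820 nM. Compound 3 holds the second highest number of the three; the steps of a 1.0-fold higher number from compound 2 to compound 3 (0.02 log units; within the scatter) and a 1.3-fold lower number from compound 1 to compound 3 (0.13 log units; within the scatter) both sit within the scatter, as does a 1.4-fold lower number from compound 1 to compound 2 (0.14 log units; within the scatter), so nothing separates these compounds on this read-out.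

Compound 4 `COc1cc2c(Oc3ccc(NC(=O)N/N=C/c4ccc(N(C)C)cc4)cc3F)ccnc2cc1OCCCN1CCCCC1` carries the change (dimethylamino in place of trifluoromethoxy on an aromatic carbon). The step that bears most directly on it is a 1.3-fold lower number from compound 1 to compound 3 (0.13 log units; within the scatter), a swap at the same aromatic carbon that moved nothing beyond the scatter; the wider aryl exchanges a 1.4-fold lower number from compound 1 to compound 2 (0.14 log units; within the scatter) and a 1.0-fold higher number from compound 2 to compound 3 (0.02 log units; within the scatter) were likewise flat. For the measured compounds named here, no measured compound carries dimethylamino, so the expectation rests on these three flat steps alone and carries extra uncertainty. On that basis no step beyond the scatter is expected in this assay, and the step from compound 3 is estimated as a 1.2-fold higher number from compound 3 to compound 4 (0.09 log units; within the scatter). Compound 4 is expected to give about 1000 nM, with a range from 400 nM to 2800 nM.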

Compound 4, half-maximal inhibitory concentration: 1400 nM
Compound 4: middle estimate off by 1.4-fold (0.15 log units), on the low side; measured number inside the range.
By their numbers in this assay, from the lowest: compounds 2, 3, 1 and 4 (each within the scatter of the next).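

Among the compounds shown here, compound 4 is the first member whose aryl terminus carries no halogen: dimethylamino, with 3 heavy atoms, replaces trifluoromethoxy, with 5, on an aromatic carbon para to a large group, and the step stays within the scatter in this assay (a 1.7-fold higher number from compound 3 to compound 4 (0.23 log units; within the scatter)). The same holds against the other two aryl termini, both for dimethylamino in place of trifluoromethyl (a 1.3-fold higher number from compound 1 to compound 4 (0.10 log units; within the scatter)) and for 4-(dimethylamino)phenyl in place of 2-chloro-4-fluorophenyl (a 1.8-fold higher number from compound 2 to compound 4 (0.25 log units; within the scatter)), so the flat picture at this position now spans fluorinated, chlorinated and halogen-free termini, and all four compounds remain unseparated on this read-out. No supporting measurement is available to explain why this exchange leaves the number within the scatter.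

Still open, as far as these compounds go, is whether a carboxylic acid, a primary amine or a morpholine ring on this aromatic carbon would also stay within the scatter, or whether a larger change at the aryl terminus is needed to separate members. From the compounds shown here alone, the shared core is constant across all four compounds, so what a change elsewhere would do in this assay remains unknown.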